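This account rests on a few compounds, and the source may have more. Where it says the series, first, only, none or still open, it means among the compounds named here.

Working notes on the series. For the measured compounds named here, compound 3 `CC(C)(C)N(NC(=O)c1cccc(Br)c1)C(=O)c1ccccc1Cl` gives 191 nM in an assay on cells for agonist activity at ecdysone receptor (Bombyx mori), read by a luciferase reporter, with a stated time of 24 h (a lower number here means that less compound is needed, a higher number that more compound is needed for the effect), and stands second highest of the three numbers measured so far. Its nearest neighbour is compound 1 `CC(C)(C)N(NC(=O)c1ccccc1)C(=O)c1ccccc1F` with 309 nM, a gap within the scatter, so no order between them can be claimed. Its furthest is compound 2 `Cc1cc(C)cc(C(=O)N(NC(=O)c2ccccc2)C(C)(C)C)c1` with 69.2 nM, a lower number beyond the scatter. Going by the values given here, the only measured step, a 4.5-fold lower number from compound 1 to compound 2 (0.65 log units; beyond the scatter), concerns a different carbonyl carbon of the shared core and does not bear directly on the present change. Compound 4 `COc1ccc(C(=O)NN(C(=O)c2ccccc2Cl)C(C)(C)C)cc1` differs from compound 3 by 4-methoxyphenyl in place of 3-bromophenyl on a carbonyl carbon. Among the compounds with values here, no measured pair in the set varies this carbonyl carbon, so the direction rests on the change itself rather than on a demonstrated step. The unsubstituted phenyl on this carbonyl carbon in compound 1 and the 3-bromophenyl in compound 3 sit within the scatter of each other, which suggests this ring tolerates substitution without a large penalty. For compound 4 a step of a 1.7-fold lower number from compound 3 to compound 4 (0.24 log units; within the scatter) is expected, meaning a modest lower number, though a result within the scatter cannot be excluded. The estimate for compound 4 in this assay is 110 nM, with a range from 40 nM to 350 nM.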

Compound 4, half-maximal effective concentration: 51.3 nM
The estimate for compound 4 lay 2.1-fold (0.33 log units) above the measured number, within the range that was stated.
By their numbers in this assay, from the lowest: compounds 4 and 2 (each within the scatter of the next); then compounds 3 and 1 (each within the scatter of the next).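

At the carbonyl carbon whose other neighbour is the amide-type nitrogen, this assay now gives a first measured step: 4-methoxyphenyl in place of 3-bromophenyl yields a 3.7-fold lower number from compound 3 to compound 4 (0.57 log units; beyond the scatter), which shows that the choice of substituted phenyl at this place can move the number beyond the scatter. For the compounds shown here, the earlier compounds gave no single-change comparison here, so this pair is the only direct reading of this position, and the direction it gives applies only to this exchange on this shared core. The change is compound in nature, since the substituent differs, its number in the group name differs, and 1 hydrogen-bond acceptor enters where 0 leave, so the step cannot be assigned to any one of these differences.

Still open, as far as these compounds go, is how the same ring would read with the methoxy group at the 3-position, or with bromine at the 4-position, which would separate the substituent from its place. Also open, from the compounds shown here alone, is how an amine, a carboxylic acid or a longer chain such as ethoxy would read on this ring, and whether the step holds when the other carbonyl carbon carries a different ring. No measurement at hand accounts for the step.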